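Bromo to methyl on the aromatic ring

The compounds below may be only part of what the source reports. "The series", "measured", "known", "first", "only" and "open" are said of these compounds alone.

In a functional assay on MCF7 cells (Homo sapiens) for inhibition, read by sulforhodamine B assay (a higher number here means a weaker inhibitor, a lower number a stronger inhibitor), compound 1 `O=C1C(Nc2ccc(I)cc2)=CC(=O)c2c1nc1n2[C@H]2OC[C@@H](O)[C@H]2OC1` gives 3890 nM and compound 3 `O=C1C(Nc2ccc(Br)cc2)=CC(=O)c2c1nc1n2[C@H]2OC[C@@H](O)[C@H]2OC1` gives 4330 nM, so compound 3 stands within the scatter of compound 1. For compound 2 `O=C1C(Nc2ccccc2)=CC(=O)c2c1nc1n2[C@H]2OC[C@@H](O)[C@H]2OC1` the result is only a limit, > 4000 nM.

Compound 4 `Cc1ccc(NC2=CC(=O)c3c(nc4n3[C@H]3OC[C@@H](O)[C@H]3OC4)C2=O)cc1` follows from compound 3 by methyl in place of bromo on an aromatic carbon, with methyl in place of bromo on an aromatic carbon, para to a large group. The two readable changes at this place are small: a 1.1-fold higher number from compound 1 to compound 3 (0.05 log units; within the scatter) and an at least 1.0-fold higher number from compound 1 to compound 2 (0.01 log units; that floor lies within the scatter). Neither leaves the scatter, so no step beyond the scatter is expected in this assay. The expected step is a 1.0-fold lower number from compound 3 to compound 4 (0.01 log units; within the scatter). Compound 4 is estimated at 4200 nM, with an expected range of 2600 nM to 6500 nM.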

Compound 4, half-maximal inhibitory concentration: > 4000 nM
Compound 4 ended at the assay's limit; the forecaster's own chance of this, stated with the estimate: 35%; the middle value is on the limit's open side.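

Methyl at this place, para to a large group, gives a second compound at the limit of this assay, alongside hydrogen in compound 2: the limit of > 4000 nM in this assay, at which 2 of the 4 values shown sit.

Going by these compounds alone, the only readable step is an at least 1.0-fold higher number from compound 1 to compound 4 (0.01 log units; that floor lies within the scatter), while the steps to compound 4 from compound 2 and compound 3 cannot be read. Across iodo, bromo, hydrogen and methyl, no readable step at this place leaves the scatter.

Going by these compounds, how far methyl lies from bromo remains open. Also open, on these data alone, is whether an amine or a carboxylic acid at this place would give a step beyond the scatter.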